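Changing the Pyridyl Arm of Compound 2

A few compounds are considered here, and "the series" means these few. Any claim that something is new, unique, unknown or untested is made for them only; others in the source may bear on it.

Compound 1 `CC(C)c1cc2c(N/N=C\c3cccnc3)ncnc2s1` and compound 2 `CC(C)(C)c1cc2c(N/N=C\c3cccnc3)ncnc2s1` share a core and carry a pyridin-3-yl group on a carbon double-bonded to nitrogen. Within the data shown here, in a functional assay on PC-6 cells (Homo sapiens) for antiproliferative activity (on this read-out higher numbers stand for weaker inhibition and lower numbers for stronger inhibition), compound 1 gives 0.889 ug/mL, and compound 2 gives 1.45 ug/mL; the single measured step, a 1.6-fold higher number from compound 1 to compound 2 (0.21 log units; within the scatter), concerns a different part of the molecule. Compound 3 `Cc1cccc(/C=N\Nc2ncnc3sc(C(C)(C)C)cc23)n1` carries 6-methylpyridin-2-yl in place of pyridin-3-yl on a carbon with a double bond to nitrogen. No measured step touches the pyridyl group, so nothing shown bears directly on this change, and the estimate is wide and centred near compound 2. For compound 3 the expected result is 2 ug/mL, within the range 0.5 ug/mL to 8 ug/mL. The step of a 1.4-fold higher number from compound 2 to compound 3 (0.14 log units; within the scatter) is thus expected to stay within the usual scatter.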

Compound 3, half-maximal inhibitory concentration: 0.258 ug/mL
For compound 3 the middle estimate is 7.8-fold (0.89 log units) above the measured one; measured number below the stated range.
By their numbers in this assay, from the lowest: compound 3; then compounds 1 and 2 (each within the scatter of the next).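

Replacing pyridin-3-yl with 6-methylpyridin-2-yl on the carbon with a double bond to nitrogen gives a 5.6-fold lower number from compound 2 to compound 3 (0.75 log units; beyond the scatter) in this assay, so this arm can clearly shift the read-out towards stronger inhibition. Among these compounds, the only earlier step, made elsewhere in the molecule, stayed within the scatter. No evidence at hand accounts for this gain.

The swap alters both the ring's attachment point and the methyl group, so the two contributions cannot be separated. A plain pyridin-2-yl group would separate them, and a 6-methoxypyridin-2-yl group would test what the methyl position tolerates.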